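The source may hold more compounds than are shown below. What is called first, only, known or untested is meant among the compounds shown, and "the series" means these compounds.

Compound 1 `CC(C)CC(=O)N[C@@H](C(=O)N1CCC(c2ccc(Cl)cc2)CC1)C(C)C` stands second highest of the three numbers measured in an assay on THP-1 cells for displacement of a labelled ligand from C-C chemokine receptor type 1 (Homo sapiens) (a lower number here means a stronger inhibitor, a higher number a weaker inhibitor), where compound 1 gives 32 nM. Compound 2 `Cc1cccc(CCC(=O)N[C@@H](C(=O)N2CCC(c3ccc(Cl)cc3)CC2)C(C)C)c1` gives 22 nM in this assay, and compound 3 `CC(C)[C@@H](NC(=O)CC1CC1)C(=O)N1CCC(c2ccc(Cl)cc2)CC1` gives 46 nM. Compound 4 `CC[C@@H](C)[C@@H](NC(=O)CC(C)C)C(=O)N1CCC(c2ccc(Cl)cc2)CC1` differs from compound 1 by methyl in place of hydrogen on a saturated chain carbon, three bonds along the chain from an amide-type nitrogen and a carbonyl carbon. For the measured compounds named here, none of the measured steps touches that position: a 1.5-fold lower number from compound 1 to compound 2 (0.16 log units; within the scatter) and a 1.4-fold higher number from compound 1 to compound 3 (0.16 log units; within the scatter) both alter the group on the saturated chain carbon bound to a carbonyl carbon and stay within the scatter, while a 2.1-fold higher number from compound 2 to compound 3 (0.32 log units; beyond the scatter) is modest. Going by the values given here, a methyl entering at a position none of the measured changes touches therefore gives no basis to expect a step beyond the scatter in this assay. Compound 4 is expected to give 35 nM, within a range of 15 nM to 85 nM, which is estimated as a step of a 1.1-fold higher number from compound 1 to compound 4 (0.04 log units; within the scatter).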

Compound 4, half-maximal inhibitory concentration: 34 nM
Compound 4: the middle estimate sits 1.0-fold (0.01 log units) above what was measured; the measured number falls inside the stated range.
By their numbers in this assay, from the lowest: compounds 2, 1, 4 and 3 (each within the scatter of the next, the first and the last beyond it).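

For the compounds shown here, until now, every change sat on the saturated chain carbon bound to a carbonyl carbon; compound 4 is the first to alter a saturated chain carbon three bonds along the chain from an amide-type nitrogen and a carbonyl carbon. In this assay the change from isopropyl to sec-butyl gives a 1.1-fold higher number from compound 1 to compound 4 (0.03 log units; within the scatter) and so shows that this position tolerates one added methyl. Nothing measured here gives a reason for this result.

Still open, on these data alone, is how a phenyl ring or an amine at this position would behave in this assay. One methyl cannot show how much larger a group could be.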